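This account rests on a few compounds, and the source may have more. Where it says the series, first, only, none or still open, it means among the compounds named here.

Measured compounds, with their readings in an ADME assay on Akata cells (Homo sapiens) for cytotoxicity, with a stated time of 7 days; a higher number here means that more compound is tolerated, a lower number that less compound is tolerated:

Compound 1 `CC(C)CSc1nc(N)nc2c1ncn2/C=C1/CC1(CO)CO`: in this assay compound 1 gives > 20000 nM, which is a limit of the assay and not a number.
Compound 2 `CN(C)c1nc(N)nc2c1ncn2/C=C1/CC1(CO)CO`: in this assay compound 2 gives > 24000 nM, again a limit rather than a number.
Compound 3 `Nc1nc2c(ncn2/C=C2/CC2(CO)CO)c(=O)[nH]1`: in this assay compound 3 gives > 20000 nM, also a limit.

Compound 2 therefore stands only at a limit in this assay; the two further readings shown are limits as well, so no compound in the set has a measured value. Within the data shown here, the one measured step that touches compound 2 is a step that the two limits leave unreadable from compound 1 to compound 2, and it cannot be read, because both ends sit at limits the limit of > 20000 nM in this assay, at which 2 of the 3 values shown sit (the limit of > 24000 nM in this assay, at which 1 of the 3 values shown sits).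

Compound 4 `CCCCCCSc1nc(N)nc2c1ncn2/C=C1/CC1(CO)CO` differs from compound 2 as follows: hexylsulfanyl in place of dimethylamino on an aromatic carbon. Among the measured compounds shown here, no measured step bears on this change with a readable size; the only related step, a step that the two limits leave unreadable from compound 1 to compound 2, is unreadable. Nothing in the numbers shown gives a reason to expect a step beyond the scatter in this assay, and the expectation is that compound 4 again reaches the limit. On that basis compound 4 is estimated at 30000 nM, in the range 12000 nM to 80000 nM, an expected step that the limit leaves unreadable from compound 2 to compound 4.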

Compound 4, half-maximal cytotoxic concentration: > 20000 nM
Compound 4: only a limit was reported; the forecaster's own chance of this, stated with the estimate: 80%; the middle value lies beyond the limit too.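

In this assay compound 4 gives > 20000 nM, a limit and not a number, so its steps from compound 1 and from compound 2 cannot be read. The compounds shown leave open at what concentration any of them becomes cytotoxic to these cells, and whether the group on the aromatic carbon alters that concentration.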